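The compounds below may be only part of what the source reports. "The series", "measured", "known", "first", "only" and "open" are said of these compounds alone.

Measured so far in a functional assay on SMMC-7721 cells (Homo sapiens) for cytotoxicity, read by MTT assay, with a stated time of 72 h; on this read-out lower numbers stand for stronger inhibition and higher numbers for weaker inhibition:

- compound 1, `COCNc1n[n+]([O-])c2ccccc2[n+]1[O-]`: 2480 nM
- compound 2, `CC(OCNc1n[n+]([O-])c2ccccc2[n+]1[O-])c1ccccc1`: 2470 nM

Two compounds share the core and differ only in the group on the carbon bound to the amine nitrogen. In this assay compound 1 gives 2480 nM and compound 2 gives 2470 nM; the two numbers sit together and their gap lies within the scatter, so neither compound can be set apart from the other on these data. Among the compounds with values here, compound 1 therefore stands at the same level as the only other measured compound.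

The next compound, compound 3, `CCCOCNc1n[n+]([O-])c2ccccc2[n+]1[O-]`, is to be measured in this assay. It differs from compound 1 by ethyl in place of hydrogen on a saturated chain carbon bound to an oxygen on a saturated carbon; cut one bond further out, the change reads methoxy to propoxy. Within the data shown here, no step between measured compounds is available to calibrate such a change. Compound 2, carrying a larger group at the same place, gives a number indistinguishable from that of compound 1, which argues against any sizeable effect of lengthening the chain here. The expected step from compound 1 to compound 3 is therefore a 1.0-fold lower number from compound 1 to compound 3 (0.01 log units; within the scatter), none beyond the scatter. Compound 3 is estimated at 2400 nM, within 1200 nM to 5000 nM.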

Compound 3, half-maximal inhibitory concentration: 5530 nM
Beside the measured number, compound 3's estimate is 2.3-fold (0.36 log units) below it, outside the stated range (above it).
By their numbers in this assay, from the lowest: compounds 2 and 1 (each within the scatter of the next); then compound 3.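

In this assay, within the data shown here, the saturated chain carbon bound to an oxygen on a saturated carbon proves not to be an indifferent place: ethyl in place of hydrogen gives a 2.2-fold higher number from compound 1 to compound 3 (0.35 log units; beyond the scatter) and so provides the first step beyond the scatter, though a modest one. Methoxy to propoxy therefore weakens inhibition in this assay, which the closeness of the two earlier compounds did not reveal. Size alone does not order the series, however: compound 2 goes against any reading that a larger group here raises the number, since its larger group leaves compound 2 at 2470 nM in the company of compound 1, whereas compound 3 stands clearly higher.

From the compounds shown here alone, it remains open whether a longer chain such as butoxy would raise the number further or whether the effect stops at propoxy. Going by these compounds, it is equally open how a propoxy chain ending in an amine or a carboxylic acid would read in this assay. Nothing measured alongside these numbers accounts for the step from methoxy to propoxy.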